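The source may report more compounds than this note shows. Statements on the series, on what has been measured and on what is new or still open speak of the compounds shown alone.

Measured compounds in a functional assay on A2780 cells (Homo sapiens) for antiproliferative activity, with a stated time of 3 days; on this read-out higher numbers stand for an effect only at larger amounts of compound and lower numbers for an effect already at smaller amounts:
Compound 1 `COCCOc1cc(-c2ccc3nc(NC(C)=O)cn3n2)cnc1N` gives 900 nM.
Compound 2 `COc1cc(-c2ccc3nc(NC(C)=O)cn3n2)cnc1N` gives 2200 nM.
Compound 3 `COc1cc(-c2ccc3nc(NC(C)=O)cn3c2)cnc1N` gives 2000 nM.

Compound 1 and compound 2 share a core and differ in one place: methoxymethyl in place of hydrogen on a saturated chain carbon bound to an oxygen on an aromatic ring. This change gives a 2.4-fold lower number from compound 2 to compound 1 (0.39 log units; beyond the scatter).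

Compound 3 carries a different core; the difference between the two cores is not broken down here. Compound 3 and compound 2 show numbers in this assay that lie within the scatter of each other.

Compound 4 `COCCOc1cc(-c2ccc3nc(NC(C)=O)cn3c2)cnc1N`, not yet measured, is built from compound 3 by the same change: methoxymethyl in place of hydrogen on a saturated chain carbon bound to an oxygen on an aromatic ring. The place of the change is the same in both pairs. If the change carries over to the core of compound 3, the step from compound 3 to compound 4 is expected to be about a 2.2-fold lower number from compound 3 to compound 4 (0.35 log units; beyond the scatter), resting on the step of a 2.4-fold lower number from compound 2 to compound 1 (0.39 log units; beyond the scatter) seen between compound 2 and compound 1. Compound 4 is therefore estimated at 900 nM, with a likely range from 400 nM to 2000 nM.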

Compound 4, half-maximal effective concentration in the A2780 assay: 5100 nM
Compound 4: middle estimate off by 5.7-fold (0.75 log units), on the low side; the whole stated range lies below it.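

In the A2780 assay compound 4 gives 5100 nM, and replacing methoxy with 2-methoxyethoxy on the core of compound 3 gives a 2.6-fold higher number from compound 3 to compound 4 (0.41 log units; beyond the scatter), so the change does not carry over from the core of compound 1 with the same direction. The two steps differ clearly, one toward a lower number and the other toward a higher one: the same change on two cores in the A2780 assay, a 2.4-fold lower number (0.39 log units; beyond the scatter) from compound 2 to compound 1 and a 2.6-fold higher number (0.41 log units; beyond the scatter) from compound 3 to compound 4, 6.2-fold (0.79 log units) apart, beyond the scatter of two such steps This shows that, in these two pairs, the outcome of the change depends on the core, but it does not show which feature of the cores decides this or how a third core would behave. In a physicochemical assay for solubility, in phosphate buffer, at pH 7.4 (a lower number here means a less soluble compound, a higher number a more soluble compound), compound 3 gives 160000 nM and compound 4 gives 110000 nM, two values within the scatter of each other.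

As far as these compounds go, it remains open whether a longer chain, or a chain ending in an amine or a carboxylic acid, would also split between the two cores.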